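Replacing tert-butyl with fluoro on an aromatic carbon

The source may hold more compounds than are shown below. What is called first, only, known or untested is meant among the compounds shown, and "the series" means these compounds.

The series has only one numerical result so far. In a functional assay on CWR22R cells (Homo sapiens) for antiproliferative activity, with a stated time of 96 h (a lower number here means a stronger inhibitor, a higher number a weaker inhibitor), compound 1 `Cc1cc(=O)oc2cc(OCC(=O)c3ccc(C(C)(C)C)cc3)ccc12` gives 22300 nM. In the same test, compound 2 `COc1cccc(C(=O)COc2ccc3c(C(F)(F)F)cc(=O)oc3c2)c1` is recorded as "not active" (no number reported). Compound 3 `CC(C)(C)c1ccc(C(=O)COc2ccc3c(C(F)(F)F)cc(=O)oc3c2)cc1` is also recorded as "not active" (no number reported). Compound 3 therefore has no position on the numerical scale: it shares its outcome with compound 2 and offers no exact starting value for the next comparison.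

Compound 4 `O=C(COc1ccc2c(C(F)(F)F)cc(=O)oc2c1)c1ccc(F)cc1` has not yet been measured. The step of interest is fluoro in place of tert-butyl on an aromatic carbon, with fluoro in place of tert-butyl on an aromatic carbon, para to a large group. Within the data shown here, no measured pair shows what such a change does, so neither the size nor the direction of a step can be derived from the data. With compound 3 at "not active" (no number reported), no clear gain in this assay is expected, and another result without a number is the likeliest outcome. If a number is obtained, it is expected to lie near that of compound 1, which gives 22300 nM, with no difference beyond the scatter. The estimated half-maximal inhibitory concentration for compound 4 is 30000 nM, with an expected range of 10000 nM to 80000 nM.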

Compound 4, half-maximal inhibitory concentration: "not active" (no number reported)
The entry for compound 4 holds no number; no gap can be computed for the estimate.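

In this assay compound 3 and compound 4 are both recorded as not active without a number, so no step can be read for fluoro in place of tert-butyl. The compounds shown leave open what this change does where a number is obtained. No measured evidence bears on this result.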